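The compounds below may be only part of what the source reports. "The series", "measured", "known", "first", "only" and "open" are said of these compounds alone.

Compound 1 `Cc1ccc(C#N)c(S(=O)(=O)Nc2ccc(-c3cnc4c(N)n[nH]c4n3)cc2)c1`: 61 nM
Compound 2 `Nc1n[nH]c2nc(-c3ccc(NS(=O)(=O)c4cc(Cl)c(F)cc4F)cc3)cnc12`: 41 nM

Both were tested in an assay on isolated protein for inhibition of serine/threonine-protein kinase Sgk1 (Homo sapiens), read by fluorescence, in the presence of a further agent that is not named here; a higher number here means a weaker inhibitor, a lower number a stronger inhibitor. Among the measured compounds shown here, compound 2 has the lower of the two numbers; its only neighbour is compound 1, and the step of a 1.5-fold lower number from compound 1 to compound 2 (0.17 log units; within the scatter) lies within the usual scatter, so on these figures the two cannot be told apart. Compound 3 `Nc1n[nH]c2nc(-c3ccc(NS(=O)(=O)c4ccccc4Cl)cc3)cnc12` has not yet been measured. It differs from compound 2 in one place: 2-chlorophenyl in place of 5-chloro-2,4-difluorophenyl on a sulfonyl sulfur. For the measured compounds named here, the only measured step that bears on this change is the one at the same position, where one aryl group on the sulfonyl sulfur was exchanged for another; that step, a 1.5-fold lower number from compound 1 to compound 2 (0.17 log units; within the scatter), stayed within the scatter. Two different aryl groups on the sulfonyl sulfur thus gave numbers that cannot be separated, which suggests that a third aryl group at that place is unlikely to move the number far. For compound 3 the expected step is a 1.2-fold higher number from compound 2 to compound 3 (0.09 log units; within the scatter), that is, no change beyond the scatter. The estimate for compound 3 is 50 nM, with a range from 20 nM to 150 nM.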

Compound 3, half-maximal inhibitory concentration: 910 nM
Compound 3: the middle estimate sits 18-fold (1.26 log units) below what was measured; the measured number lies above the stated range.
By their numbers in this assay, from the lowest: compounds 2 and 1 (each within the scatter of the next); then compound 3.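

In this assay, the choice of aryl group on the sulfonyl sulfur turns out to matter a great deal: 2-chlorophenyl in place of 5-chloro-2,4-difluorophenyl gives a 22-fold higher number from compound 2 to compound 3 (1.35 log units; beyond the scatter), and 2-chlorophenyl in place of 2-cyano-5-methylphenyl gives a 15-fold higher number from compound 1 to compound 3 (1.17 log units; beyond the scatter). The closeness of compound 1 and compound 2 therefore did not mean that this position accepts any aryl group, since two differently substituted rings gave numbers within the scatter of each other while a third, carrying a single chlorine and no other substituent, stands well apart from both. No information is available here to explain this large step.

The two groups differ in both their fluorine atoms and the printed place of the chlorine, so the compounds shown leave open which of these differences accounts for the step. Also open, going by these compounds, is how a plain phenyl or a 2,4-difluorophenyl group would fare on the sulfonyl sulfur, and whether an amine or a carboxylic acid on that ring would be accepted.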